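This account rests on a few compounds, and the source may have more. Where it says the series, first, only, none or still open, it means among the compounds named here.

Compound 1 `Cc1cc(C)c2cccc(OCc3c(Cl)ccc(S(=O)(=O)NC4(C(=O)N5CCN(C(=O)CCCCC[N+](C)(C)C)CC5)CCCC4)c3Cl)c2n1`: in an assay on isolated protein for binding affinity to B1 bradykinin receptor (Homo sapiens) (on this read-out lower numbers stand for stronger inhibition and higher numbers for weaker inhibition), compound 1 gives < 10000 nM, which is a limit of the assay and not a number.
Compound 2 `Cc1cc(C)c2cccc(OCc3c(Cl)ccc(S(=O)(=O)NC4(C(=O)N5CCN(C(=O)[C@H](CCCC[N+](C)(C)C)[N+](C)(C)C)CC5)CCCC4)c3Cl)c2n1`: in this assay compound 2 gives < 10000 nM, again a limit.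
Compound 3 `Cc1cc(C)c2cccc(OCc3c(Cl)ccc(S(=O)(=O)NC4(C(=O)N5CCN(C(=O)[C@H](CCCCN)[N+](C)(C)C)CC5)CCCC4)c3Cl)c2n1`: in this assay compound 3 gives < 10000 nM, also a limit.

Compound 1 therefore stands nowhere on a scale of numbers; it sits at the limit of < 10000 nM in this assay, at which 3 of the 3 values shown sit, together with the other two values shown. The steps a step that the two limits leave unreadable from compound 1 to compound 2, a step that the two limits leave unreadable from compound 1 to compound 3 and a step that the two limits leave unreadable from compound 2 to compound 3 cannot be read, since both ends of each lie at the same limit.

Compound 4 `Cc1cc(C)c2cccc(OCc3c(Cl)ccc(S(=O)(=O)NC4(C(=O)N5CCN(C(=O)CCC[N+](C)(C)C)CC5)CCCC4)c3Cl)c2n1` differs from compound 1 by a group of 4 heavy atoms (3 carbon, 1 nitrogen; no ring) in place of a group of 6 heavy atoms (5 carbon, 1 nitrogen; no ring), on a saturated chain carbon, three bonds along the chain from a carbonyl carbon. The change sits in the same side chain that the measured steps alter, but those steps give no readable size, so they set no direction for this one. What the series shows is only that three variations of this chain, including a longer one and ones with added charged or amine groups, all stay at the limit in this assay.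

The expectation for compound 4 is accordingly a value at or near the same limit, with the step from compound 1 estimated as a step that the limit leaves unreadable from compound 1 to compound 4. Compound 4 is estimated at 8000 nM, with a range from 2000 nM to 30000 nM, and most likely the assay will again report only a limit.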

Compound 4, inhibition constant: < 10000 nM
Compound 4 gave a limit, no number (the forecaster's own chance of this, stated with the estimate: 80%); the middle value is on the limit's open side.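

Neither the step from compound 1 to compound 4 nor the one from compound 3 to compound 4 can be read in this assay, since both ends of each lie at one limit: the limit of < 10000 nM in this assay, at which 4 of the 4 values shown sit.

The compounds shown leave open where any of the four stands on a scale of numbers, and whether these side-chain changes shift the read-out at all.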